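Diaryl hydrazone ureas: swapping the benzylic amine

This account rests on a few compounds, and the source may have more. Where it says the series, first, only, none or still open, it means among the compounds named here.

Compounds measured in a functional assay on MCF7 cells (Homo sapiens) for antiproliferative activity, read by CCK-8 assay, with a stated time of 24 h; on this read-out lower numbers stand for stronger inhibition and higher numbers for weaker inhibition:
compound 1 `C/C(=N\NC(=O)Nc1ccc(CN2CCC(C)CC2)cc1)c1ccccn1` — > 40000 nM
compound 2 `CN(C)Cc1ccc(NC(=O)NN=C(c2ccccc2)c2ccccc2)cc1` — 12100 nM
compound 3 `CCN(CC)Cc1ccc(NC(=O)NN=C(c2ccccc2)c2ccccc2)cc1` — 13100 nM

Compound 1, with the core of compound 1, returns only a limit of this assay, > 40000 nM, so no number is known for it (the limit of > 40000 nM in this assay, at which 1 of the 3 values shown sits). Compound 2 and compound 3 share the other core; compound 2 gives 12100 nM and compound 3 gives 13100 nM; the step of a 1.1-fold higher number from compound 2 to compound 3 (0.03 log units; within the scatter) lies within the scatter, so the two values stand together and neither can be put above the other.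

Compound 4 `CC1CCN(Cc2ccc(NC(=O)NN=C(c3ccccc3)c3ccccc3)cc2)CC1` has not yet been measured in this assay. It differs from compound 3 by 4-methylpiperidin-1-yl in place of diethylamino on a saturated chain carbon bound to an aromatic carbon. Within the data shown here, the only measured step that bears on this change is a 1.1-fold higher number from compound 2 to compound 3 (0.03 log units; within the scatter), which shows that exchanging one small alkylamine for another at this position left the number essentially where it was. Compound 1 carries the same 4-methylpiperidin-1-yl group but on a different core and gives only a limit, so it cannot be read as a step.

On that basis the expected step is a 1.1-fold higher number from compound 3 to compound 4 (0.06 log units; within the scatter), that is, no change beyond the scatter. Compound 4 is therefore estimated at 15000 nM, with a likely range from 6000 nM to 40000 nM.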

Compound 4, half-maximal inhibitory concentration: 13300 nM
The estimate for compound 4 lay 1.1-fold (0.05 log units) above the measured number; low and high end bracket the measured number.
By their numbers in this assay, from the lowest: compounds 2, 3 and 4 (each within the scatter of the next). At a limit, above all of these: compound 1.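

The earlier step on this core exchanged one open-chain amino group for another, whereas here a ring enters the same place, on a saturated chain carbon bound to an aromatic carbon. With 4-methylpiperidin-1-yl in place of diethylamino, this assay gives a 1.0-fold higher number from compound 3 to compound 4 (0.01 log units; within the scatter) and, against dimethylamino, a 1.1-fold higher number from compound 2 to compound 4 (0.04 log units; within the scatter) as the second comparison. The values for compound 2, compound 3 and compound 4 therefore stand together on the shared core, and a six-membered non-aromatic ring at this place, carrying its methyl group, is not separated from either open-chain amine.

Among these compounds, compound 1 carries the same 4-methylpiperidin-1-yl group on its other core and gives only a limit, so no step between the two cores can be read: the limit of > 40000 nM in this assay, at which 1 of the 4 values shown sits. Still open, on these data alone, is whether a different kind of group at this place, such as morpholine, a primary amine or a carboxylic acid, would move the number on the shared core, and whether the amines that stand together there would also do so on the core of compound 1.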